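A chlorophenyl in place of a methylthiophene

The source may hold more compounds than are shown below. What is called first, only, known or untested is meant among the compounds shown, and "the series" means these compounds.

Among the compounds with values here, in an ADME assay on HepG2 cells (Homo sapiens) for cytotoxicity, read by MTT assay, with a stated time of 48 h (a lower number here means a stronger inhibitor, a higher number a weaker inhibitor), compound 3 `Cc1ccsc1/C=C1\S/C(=N\c2ccccc2)N(CC(C)C)C1=O` gives 89200 nM as the only true number in this small set. Compound 2 `CC(C)CN1C(=O)/C(=C/c2ccc(N(C)C)cc2)S/C1=N\c1ccccc1` gives > 100000 nM as a limit of the assay and not a number. Compound 1 `CC(C)CN1C(=O)/C(=C/c2ccc(Cl)cc2)S/C1=N\c1ccccc1` has "not determined" (no result reported) as its entry and offers no guide.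

Compound 4 `CC(C)CN1C(=O)/C(=C/c2cccc(Cl)c2)S/C1=N\c1ccccc1` now follows, with 3-chlorophenyl in place of 3-methylthiophen-2-yl on a double-bonded chain carbon bound to a double-bonded ring carbon, and 3-chlorophenyl in place of 3-methylthiophen-2-yl on a double-bonded chain carbon bound to a double-bonded ring carbon counts what changes.

Within the data shown here, the one measured step at that place is an at least 1.1-fold lower number from compound 2 to compound 3 (0.04 log units; that floor lies within the scatter) and only its floor is known, which lies within the scatter. That floor rests on the limit of > 100000 nM in this assay, at which 1 of the 3 values shown sits, and so sets no firm size. Little therefore points to a move beyond the scatter, so a 1.1-fold lower number from compound 3 to compound 4 (0.05 log units; within the scatter) is what is expected in this assay for now. For compound 4 the estimate is 80000 nM with an expected range from 35000 nM to 150000 nM as its bounds, and a reading that returns only a limit would be no surprise.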

Compound 4, half-maximal inhibitory concentration: 88100 nM
The estimate for compound 4 lay 1.1-fold (0.04 log units) below the measured number; low and high end bracket the measured number.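

In this assay, the step is a 1.0-fold lower number from compound 3 to compound 4 (0.01 log units; within the scatter), so at this place, on a double-bonded chain carbon bound to a double-bonded ring carbon, 3-chlorophenyl and 3-methylthiophen-2-yl cannot be told apart. Unlike the earlier step, this one has a true number at both ends, and it shows that a five-membered aromatic ring with a sulfur atom and a six-membered carbon ring with a chlorine atom can stand here with no change beyond the scatter. The other new step is an at least 1.1-fold lower number from compound 2 to compound 4 (0.05 log units; that floor lies within the scatter), and only its floor is known: the limit of > 100000 nM in this assay, at which 1 of the 4 values shown sits.

Compound 1 gives "not determined" (no result reported), so it offers no comparison with compound 4. Whether any group at this place moves the number beyond the scatter stays open, since every group shown is an aromatic ring, and a carboxylic acid or a saturated amine ring does not appear among them.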